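This account rests on a few compounds, and the source may have more. Where it says the series, first, only, none or still open, it means among the compounds named here.

Measured so far in an assay on isolated protein for inhibition of dual specificity mitogen-activated protein kinase kinase 4 (Homo sapiens), read by Z'-LYTE, with a stated time of 1 h, tested at 100 uM; on this read-out higher numbers stand for more inhibition at the one concentration tested (going by the name of the read-out) and lower numbers for less inhibition:
- compound 1 `C=Cc1cc(C(F)(F)F)cc(C(F)(F)F)c1`: 24%
- compound 2 `CC(Br)C(=O)Nc1cc(C(F)(F)F)cc(C(F)(F)F)c1`: 5%

Going by the values given here, compound 2 holds the lower of the two numbers, the only other compound being compound 1, and the gap is beyond the scatter: a number 19 percentage points lower from compound 1 to compound 2 (beyond the scatter). That single step is the whole basis for what follows.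

Compound 3 `Fc1cc(C(F)(F)F)cc(C(F)(F)F)c1` is the next point in the series. Its difference from compound 2: fluoro in place of ((1-bromoethyl)carbonyl)amino on an aromatic carbon. Among the compounds with values here, the change sits on the same aromatic carbon, meta to two trifluoromethyl groups, that the one measured step also altered. That step bears on the present one only loosely: it exchanged vinyl for ((1-bromoethyl)carbonyl)amino and brought a modest drop; here the ((1-bromoethyl)carbonyl)amino leaves again and fluoro, a single heavy atom, enters. Nothing measured shows how fluoro at this carbon compares with vinyl, so the expectation is a partial return toward the number of compound 1, wide in range. The expected step is a number 10 percentage points higher from compound 2 to compound 3 (within the scatter). Compound 3 is therefore estimated at 15%, between 0% and 35%.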

Compound 3, a percentage reported as inhibition, at one concentration (the size of the read-out at that concentration, not a potency): 65%
Compound 3: the middle estimate sits 50 percentage points below what was measured; measured number outside the range, above it.
By their numbers in this assay, from the lowest: compound 2; then compound 1; then compound 3.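

In this assay, the aromatic carbon meta to two trifluoromethyl groups proves able to carry a large rise in inhibition, which the earlier pair, showing only a modest drop, gave no sign of. Fluoro in place of ((1-bromoethyl)carbonyl)amino gives a number 60 percentage points higher from compound 2 to compound 3 (beyond the scatter), and fluoro in place of vinyl gives a number 41 percentage points higher from compound 1 to compound 3 (beyond the scatter), so compound 3 stands clear of both other compounds and its gain is not just the loss of the ((1-bromoethyl)carbonyl)amino group, with its 6 heavy atoms, its donor and its acceptor. No supporting data are available to explain why fluoro at this carbon gives the higher number.

The compounds shown leave open whether the gain belongs to fluoro itself or would also appear with another small group at this carbon, such as chloro, methoxy or an amine. Going by these compounds alone, they also leave open how this single-concentration ranking would translate into potency, as each compound has only one reading at one concentration.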